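The compounds below may be only part of what the source reports. "The series", "measured", "known", "first", "only" and "open" are said of these compounds alone.

Measured so far in a physicochemical assay for permeability, using PAMPA, at pH 7.4; a lower number here means that the compound crosses the layer more slowly, a higher number that the compound crosses the layer faster:
compound 1, `CC(C)Nc1nc(NCc2ccco2)c2cccc(Cl)c2n1`: 1330 10^-6 cm/s
compound 2, `CC(C)Nc1nc(NCc2ccco2)c2cc(Cl)ccc2n1`: 1630 10^-6 cm/s
compound 3, `Cc1cccc2c(NCc3ccco3)nc(NC(C)C)nc12`: 666 10^-6 cm/s

Compounds 1 and 2 are built from the same atoms joined differently; the difference between the two cores is not broken down here. Compound 3 derives from compound 1 by methyl in place of chloro on an aromatic carbon, and the measured step is a 2.0-fold lower number from compound 1 to compound 3 (0.30 log units; within the scatter).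

Compound 4, `Cc1ccc2nc(NC(C)C)nc(NCc3ccco3)c2c1`, awaits measurement in this assay. It stands to compound 2 as compound 3 stands to compound 1, by methyl in place of chloro on an aromatic carbon. The two changes are the same kind of change, not the same: in compound 3 the place is ortho to a fused ring and meta to a fused ring, in compound 4 it is meta to a fused ring and para to a fused ring. A single prior instance is a thin basis.

For compound 4 a step of a 2.0-fold lower number from compound 2 to compound 4 (0.31 log units; beyond the scatter) is expected, resting on a 2.0-fold lower number from compound 1 to compound 3 (0.30 log units; within the scatter). Compound 4 is estimated at 800 10^-6 cm/s, between 500 10^-6 cm/s and 1300 10^-6 cm/s.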

Compound 4, apparent permeability: 789 10^-6 cm/s
Estimate against measurement, compound 4: 1.0-fold (0.01 log units) above, and the stated range covers the measured number.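

In this assay methyl in place of chloro gives a 2.1-fold lower number from compound 2 to compound 4 (0.32 log units; beyond the scatter) on the core of compound 2 and a 2.0-fold lower number from compound 1 to compound 3 (0.30 log units; within the scatter) on the core of compound 1, so the direction carries across these two cores, with only the former step printed as beyond the scatter. Two pairs, with the group at a different place on each core, do not make a rule for other cores or other places in the series. Nothing measured here bears on what lies behind either step.

From the compounds shown here alone, whether an amine, a carboxylic acid or a methoxy group in place of chloro would follow the same direction stays open. Also open, going by these compounds, is whether the step holds in other assays.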